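Methyl on the Anilide Ring of a Weakly Active Thiazole Amide

The compounds below may be only part of what the source reports. "The series", "measured", "known", "first", "only" and "open" are said of these compounds alone.

Compound 1 `O=C(NCc1ccccc1)c1csc(-c2c[nH]c3ccccc23)n1` carries a benzyl group on its amide nitrogen; in a functional assay on HeLa cells (Homo sapiens) for cytotoxicity, read by MTT assay, with a stated time of 48 h, in the presence of a further agent that is not named here (on this read-out higher numbers stand for weaker inhibition and lower numbers for stronger inhibition), compound 1 gives 41400 nM. Compound 2 `O=C(Nc1ccccc1)c1csc(-c2cn(Cc3ccc(Cl)cc3)c3ccccc23)n1` carries instead a phenyl on the amide nitrogen and a 4-chlorobenzyl on the aromatic nitrogen of the shared core, and in this assay compound 2 gives 32100 nM. Compound 3 `O=C(Nc1ccccc1)c1csc(-c2c[nH]c3ccccc23)n1` has the phenyl on the amide nitrogen and a hydrogen on the aromatic nitrogen. For compound 3 the read-out in this assay is only a limit, > 100000 nM, because the limit of > 100000 nM in this assay, at which 1 of the 3 values shown sits, is the highest value the measurement reports. The two measured steps both run toward compound 3: an at least 2.4-fold higher number from compound 1 to compound 3 (0.38 log units; beyond the scatter) and an at least 3.1-fold higher number from compound 2 to compound 3 (0.49 log units; beyond the scatter). Both therefore describe changes at a nitrogen, not on the phenyl ring itself.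

Compound 4 `Cc1ccc(NC(=O)c2csc(-c3c[nH]c4ccccc34)n2)cc1` differs from compound 3 by methyl in place of hydrogen on an aromatic carbon. No measured step touches this ring, so nothing shown points to a shift beyond the scatter in this assay. Compound 4 is therefore expected to stay near the limit, with an estimated 100000 nM and a range from 40000 nM to 250000 nM. The expected step is a number no higher from compound 3 to compound 4 (the limit leaves the size open), which may well again be reported only as a limit.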

Compound 4, half-maximal inhibitory concentration: > 100000 nM
Compound 4: a limit, no number; the forecaster's own chance of this, stated with the estimate: 60%; the middle value lies on the limit itself.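

With 4-methylphenyl on the amide nitrogen, compound 4 gives > 100000 nM in this assay, which is a limit and not a number, so a methyl on the ring itself, para to a large group, does not bring this series off the limit. The step from compound 3 cannot be read, since both compounds sit at the limit and any true change from the methyl would stay hidden: the limit of > 100000 nM in this assay, at which 2 of the 4 values shown sit.

What can be read is an at least 2.4-fold higher number from compound 1 to compound 4 (0.38 log units; beyond the scatter), so phenyl and 4-methylphenyl on the amide nitrogen, each with hydrogen on the aromatic nitrogen of the shared core, both read weaker than benzyl.

The compounds shown leave open whether another group at this same place, such as an amine or a carboxylic acid in place of the methyl, could give a readable number. They also leave open what the methyl would do alongside the 4-chlorobenzyl of compound 2, which gives 32100 nM, a value from which a shift in either direction could be seen.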